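A Dichlorophenyl Swap on the Shared Core

The source may report more compounds than this note shows. Statements on the series, on what has been measured and on what is new or still open speak of the compounds shown alone.

Compound 1 `CC(C)c1ccc(Nc2ccc3c(OCCCN4CCN(C)CC4)cccc3n2)cc1`: 1860 nM
Compound 2 `CN1CCN(CCCOc2cccc3nc(Nc4ccc(F)c(F)c4)ccc23)CC1`: 1030 nM
Compound 3 `CN1CCN(CCCOc2cccc3nc(Nc4cc(Cl)cc(Cl)c4)ccc23)CC1`: not yet measured

For the measured compounds named here, in a functional assay on LOX IMVI cells (Homo sapiens) for inhibition, read by sulforhodamine B assay, with a stated time of 48 h (on this read-out higher numbers stand for weaker inhibition of growth and lower numbers for stronger inhibition of growth), compound 2 gives 1030 nM, which lies within the scatter of compound 1, the only other measured compound. Compound 3 differs from compound 2 as follows: 3,5-dichlorophenyl in place of 3,4-difluorophenyl on a nitrogen on an aromatic ring. Going by the values given here, one measured step bears on this change at the same place: a 1.8-fold lower number from compound 1 to compound 2 (0.26 log units; within the scatter). That step stayed within the scatter and offers no direction. In this assay the expected change is a 1.1-fold lower number from compound 2 to compound 3 (0.04 log units; within the scatter), nothing beyond the scatter. Compound 3 is estimated at 950 nM, with an expected range from 420 nM to 2200 nM.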

Compound 3, concentration for 50% growth inhibition: 1580 nM
Compound 3: the middle estimate sits 1.7-fold (0.22 log units) below what was measured; the range from low to high includes it.
By their numbers in this assay, from the lowest: compounds 2, 3 and 1 (each within the scatter of the next).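

In this assay, the 3,5-dichlorophenyl group gives a 1.5-fold higher number from compound 2 to compound 3 (0.19 log units; within the scatter), and set against the 4-isopropylphenyl group it gives a 1.2-fold lower number from compound 1 to compound 3 (0.07 log units; within the scatter). Three different substituted phenyl groups on this nitrogen now sit within the scatter of one another, so this change, like the earlier one, sets no direction. No measurement shown here accounts for these numbers. The halogen and its placement change together in this swap, so 3,5-difluorophenyl would be needed to separate them. Also open, from the compounds shown here alone, is whether a phenyl carrying an amine or a carboxylic acid would move the number beyond the scatter.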